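The source may report more compounds than this note shows. Statements on the series, on what has been measured and on what is new or still open speak of the compounds shown alone.

Measured so far in a functional assay for inhibition; a lower number here means a stronger inhibitor, a higher number a weaker inhibitor:
- Compound 1 `CC(C)(C)c1cc(-c2cc(=O)c3ccc(OCc4ccc(Cl)cc4)cc3o2)cc(C(C)(C)C)c1O` gives 7000 nM
- Compound 2 `CC(C)(C)c1cc(-c2cc(=O)c3ccc(OCCCS(=O)(=O)O)cc3o2)cc(C(C)(C)C)c1O` gives 500 nM

Compound 2 holds the lower of these two numbers, which makes it the stronger inhibitor of the pair. The gap between them is a 14-fold lower number from compound 1 to compound 2 (1.15 log units; beyond the scatter) and is a large one. Next comes compound 3 `CC(C)(C)c1cc(-c2cc(=O)c3ccc(OCC(=O)N4CCCCC4)cc3o2)cc(C(C)(C)C)c1O` in which (piperidin-1-yl)carbonyl stands in place of 2-sulfoethyl on a saturated chain carbon bound to an oxygen on an aromatic ring. Going by the values given here, the counted change is (piperidin-1-yl)carbonyl in place of 2-sulfoethyl on a saturated chain carbon bound to an oxygen on an aromatic ring and it falls at the same place as the single measured step, so that step is the only guide. Compound 3 gives up the sulfo group and, like compound 1, carries a ring in the changed part. Among the compounds with values here, compound 1 at 7000 nM is the only measured compound without the sulfo group, so a move back towards it seems likely. The expected change is a 4.0-fold higher number from compound 2 to compound 3 (0.60 log units; beyond the scatter) towards a higher number, meaning a weaker inhibitor. With so little data the estimate stays broad. For compound 3 the estimated value is 2000 nM with an expected range from 450 nM to 8000 nM in this assay.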

Compound 3, half-maximal inhibitory concentration: 3000 nM
The estimate for compound 3 lay 1.5-fold (0.18 log units) below the measured number; low and high end bracket the measured number.
By their numbers in this assay, from the lowest: compound 2; then compound 3; then compound 1.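

In this assay, swapping 3-sulfopropyl for ((piperidin-1-yl)carbonyl)methyl on the oxygen of the shared core gives a 6.0-fold higher number from compound 2 to compound 3 (0.78 log units; beyond the scatter), so a second compound without the sulfo group also falls short of compound 2, which keeps the lowest number of the three. The two compounds without the sulfo group are not equivalent either: going to the (piperidin-1-yl)carbonyl group from the 4-chlorophenyl group gives a 2.3-fold lower number from compound 1 to compound 3 (0.37 log units; beyond the scatter), which shows that the number at this position depends on more than whether the sulfo group is present. Nothing available explains why these groups rank in this order.

Going by these compounds alone, with compound 2 as the only compound carrying a sulfo group, the data cannot separate the contribution of that group from that of its propyl chain, and a carboxylic acid at the end of the same chain would help to tell them apart. Going by these compounds, it also remains open how much of the result for compound 3 depends on its piperidine ring, a question that a simple dimethylamide or a morpholine amide in the same place could address.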